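Swapping methoxycarbonyl for ethoxycarbonyl on compound 3

This account rests on a few compounds, and the source may have more. Where it says the series, first, only, none or still open, it means among the compounds named here.

Compound 1 `COC(=O)c1sc2cc(OC)ccc2c1Nc1cc(OC)c(OC)c(OC)c1`: 0.28 nM
Compound 2 `CCOC(=O)c1sc2ccccc2c1Nc1cc(OC)c(OC)c(OC)c1`: 3100 nM
Compound 3 `COC(=O)c1sc2cc(C)ccc2c1Nc1cc(OC)c(OC)c(OC)c1`: 0.31 nM

All three compounds were measured in a functional assay on HeLa cells (Homo sapiens) for cytotoxicity, read by MTT assay, with a stated time of 72 h; a lower number here means a stronger inhibitor, a higher number a weaker inhibitor. There compound 3 gives 0.31 nM, within the scatter of compound 1 and far below compound 2. Compound 4 `CCOC(=O)c1sc2cc(C)ccc2c1Nc1cc(OC)c(OC)c(OC)c1` has not yet been measured. It is compound 3 with one change: methyl in place of hydrogen on a saturated chain carbon bound to an oxygen next to a carbonyl group. In words, this is methyl in place of hydrogen on a saturated chain carbon bound to an oxygen next to a carbonyl group, turning methoxycarbonyl into ethoxycarbonyl.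

Going by the values given here, no measured step covers this change directly. Among the compounds with values here, the only step available, a 1.1-fold higher number from compound 1 to compound 3 (0.04 log units; within the scatter), lies elsewhere on the molecule, on an aromatic carbon, and stays within the scatter. The nearest evidence is compound 2, which carries the same ethoxycarbonyl group but has neither the methyl nor the methoxy group of the other two. Its value of 3100 nM suggests that a higher number is to be expected for compound 4, though compound 2 differs in two places and so cannot fix the size. The expected step is a 32-fold higher number from compound 3 to compound 4 (1.51 log units; beyond the scatter), toward a weaker inhibitor, and this size is uncertain. For compound 4 the estimated value is 10 nM, with an expected range from 0.5 nM to 300 nM.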

Compound 4, half-maximal inhibitory concentration: 0.38 nM
Estimate against measurement, compound 4: 26-fold (1.42 log units) above, outside the stated range (below it).
By their numbers in this assay, from the lowest: compounds 1, 3 and 4 (each within the scatter of the next); then compound 2.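

In this assay, turning methoxycarbonyl into ethoxycarbonyl gives a 1.2-fold higher number from compound 3 to compound 4 (0.09 log units; within the scatter), so methyl in place of hydrogen on a saturated chain carbon bound to an oxygen next to a carbonyl group is tolerated, at least in a compound that also carries the methyl on the aromatic carbon. Going by these compounds alone, the earlier compounds could not show this, since the only ethoxycarbonyl compound among them, compound 2, differs from compound 3 in two places. Compound 4 now separates the two changes, and the large difference belongs to the other one, methyl in place of hydrogen on an aromatic carbon, which gives an 8200-fold lower number from compound 2 to compound 4 (3.91 log units; beyond the scatter).

Nothing available explains why one methyl matters so much and the other so little. The compounds shown leave open whether methoxycarbonyl would also give so high a number with hydrogen in place of the methyl on the aromatic carbon, and whether a longer chain, a carboxylic acid or an amide at this place would stay within the scatter of compound 4.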